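This account rests on a few compounds, and the source may have more. Where it says the series, first, only, none or still open, it means among the compounds named here.

Compound 1 `CCCc1c(Cl)c(O)cc(O)c1Oc1c(Cl)c(O)c(Cl)c2c1C(=O)O[C@@H]2CC` and compound 2 `CCCc1cc(O)c(Cl)c(O)c1Oc1c(Cl)c(O)c(Cl)c2c1C(=O)O[C@@H]2CC` share one core and differ only in where the chloro sits. In an ADME assay on MDCK cells (Canis lupus familiaris) for cytotoxicity, read by CellTiter-Glo, with a stated time of 40 h (a lower number here means that less compound is tolerated, a higher number that more compound is tolerated), compound 1 gives only a limit of the assay, > 50000 nM. In this assay compound 2 likewise gives only a limit, > 100000 nM. Both values shown are limits rather than numbers, as the limit of > 100000 nM in this assay, at which 1 of the 2 values shown sits, and the limit of > 50000 nM in this assay, at which 1 of the 2 values shown sits, record, so compound 2 has no number of its own. Compound 3 `CCCc1c(Cl)c(O)c(Cl)c(O)c1Oc1c(Cl)c(O)c(Cl)c2c1C(=O)O[C@@H]2CC` differs from compound 2 by chloro in place of hydrogen on an aromatic carbon. Among the compounds with values here, with no measured step to guide it, the expected change in this assay is an at least 1.2-fold lower number from compound 2 to compound 3 (0.09 log units; that floor lies within the scatter), none beyond the scatter. Compound 3 is therefore estimated at 80000 nM, within 30000 nM to 200000 nM, most likely again reported only as a limit.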

Compound 3, half-maximal cytotoxic concentration: > 50000 nM
Compound 3: a limit, no number; the forecaster's own chance of this, stated with the estimate: 75%; the middle value is on the limit's open side.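

Compound 3 also gives only a limit in this assay, so the steps to it from compound 1 and from compound 2 cannot be read: the limit of > 50000 nM in this assay, at which 2 of the 3 values shown sit.

The compounds shown leave open whether chloro in place of hydrogen on an aromatic carbon changes how much compound the cells tolerate.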